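A Single Fluoro Added to Compound 1

A few compounds are considered here, and "the series" means these few. Any claim that something is new, unique, unknown or untested is made for them only; others in the source may bear on it.

Compound 1 `O=C(Nc1ccc(Oc2ccnc3[nH]ccc23)cc1)c1nn(-c2ccc(Cl)cc2)ccc1=O` gives the lowest of the three numbers measured in a functional assay on MCF7 cells (Homo sapiens) for cytotoxicity, read by MTT assay, with a stated time of 72 h (a higher number here means a weaker inhibitor, a lower number a stronger inhibitor), at 10600 nM. Compound 2 `COc1ccc(-n2ccc(=O)c(C(=O)Nc3ccc(Oc4ccnc5[nH]ccc45)cc3)n2)cc1` gives 21600 nM, a step of a 2.0-fold higher number from compound 1 to compound 2 (0.31 log units; beyond the scatter). Compound 3 `O=C(Nc1ccc(Oc2ccnc3[nH]ccc23)cc1)c1nn(-c2ccc(Br)cc2F)ccc1=O` gives 17900 nM, a step of a 1.7-fold higher number from compound 1 to compound 3 (0.23 log units; within the scatter), so compound 1 and compound 3 cannot be told apart. Compound 4 `O=C(Nc1ccc(Oc2ccnc3[nH]ccc23)c(F)c1)c1nn(-c2ccc(Cl)cc2)ccc1=O` differs from compound 1 by fluoro in place of hydrogen on an aromatic carbon, the fluoro sitting ortho to a large group and meta to a large group. Going by the values given here, no measured step touches this place; all three alter the group on the aromatic nitrogen, and even the largest of them is modest. For compound 4 a step of a 1.1-fold higher number from compound 1 to compound 4 (0.05 log units; within the scatter) is therefore expected, nothing beyond the scatter. Compound 4 is estimated at 12000 nM, within 5000 nM to 30000 nM in this assay.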

Compound 4, half-maximal inhibitory concentration: > 60000 nM
Compound 4: only a limit was reported (the forecaster's own chance of this, stated with the estimate: 5%); middle value at least 5.0-fold (0.69 log units) from the limit.
By their numbers in this assay, from the lowest: compounds 1, 3 and 2 (each within the scatter of the next, the first and the last beyond it). At a limit, above all of these: compound 4.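

Unlike the earlier changes, all on the group at the aromatic nitrogen, this one sits on the other side of the amide, and one added heavy atom gives the largest step so far: an at least 5.6-fold higher number from compound 1 to compound 4 (0.75 log units; beyond the scatter). The place ortho to a large group and meta to a large group therefore does not tolerate every change in this assay. Compound 4 gives only a limit, not a number: the limit of > 60000 nM in this assay, at which 1 of the 4 values shown sits.

From the compounds shown here alone, whether only fluoro behaves this way at this place stays open; a methyl or an amine there would show it. Also open, going by these compounds, is whether the same fluoro on compound 2 or compound 3 gives a similar step.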